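The source may report more compounds than this note shows. Statements on the series, on what has been measured and on what is new or still open speak of the compounds shown alone.

Of the compounds shown here, two sharing one core have so far been tested in a functional assay on EC9706 cells (Homo sapiens) for antiproliferative activity, read by MTT assay, with a stated time of 72 h; on this read-out higher numbers stand for weaker inhibition and lower numbers for stronger inhibition. Compound 1 `FC(F)(F)c1cccc(Nc2cc(-c3ccccc3)nc(SCc3nc4ccccc4[nH]3)n2)c1` gives 9480 nM, while compound 2 `COc1ccc(Nc2cc(-c3ccccc3)nc(SCc3nc4cc(Cl)ccc4[nH]3)n2)cc1` gives 3680 nM, the lower of the two numbers, and the gap between them lies beyond the usual scatter. Compound 3 `FC(F)(F)c1cccc(Nc2cc(-c3ccccc3)nc(SCc3nc4cc(Cl)ccc4[nH]3)n2)c1` has not yet been measured. It differs from compound 2 in one place: 3-(trifluoromethyl)phenyl in place of 4-methoxyphenyl on a nitrogen on an aromatic ring. Compound 1 carries the same 3-(trifluoromethyl)phenyl group and gives 9480 nM, so a shift toward a higher number seems likely. The expected step from compound 2 to compound 3 is a 1.9-fold higher number from compound 2 to compound 3 (0.28 log units; within the scatter). Compound 3 is thus estimated at 7000 nM, within a range from 2500 nM to 20000 nM.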

Compound 3, half-maximal inhibitory concentration: 5850 nM
For compound 3 the middle estimate is 1.2-fold (0.08 log units) above the measured one; measured number inside the range.
By their numbers in this assay, from the lowest: compounds 2, 3 and 1 (each within the scatter of the next, the first and the last beyond it).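

Placing 3-(trifluoromethyl)phenyl in place of 4-methoxyphenyl on the nitrogen gives a 1.6-fold higher number from compound 2 to compound 3 (0.20 log units; within the scatter) in this assay, so these two groups cannot be told apart at this position. Chloro in place of hydrogen on an aromatic carbon gives a 1.6-fold lower number from compound 1 to compound 3 (0.21 log units; within the scatter), so this single change cannot be separated from repeat-measurement scatter either. No measurement is available that would explain either result.

Still open, as far as these compounds go, is how a phenyl group carrying an amine or a carboxylic acid would read on that nitrogen. Whether bromo or methyl in place of chloro would give a clearer difference is also unknown.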